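A Chlorophenyl Urea in Place of a Styryl Amide

The source may hold more compounds than are shown below. What is called first, only, known or untested is meant among the compounds shown, and "the series" means these compounds.

Measured so far:
compound 1 `COc1cc(NC(C)CCCNC(=O)Nc2cc(C(F)(F)F)cc(C(F)(F)F)c2)c2ncccc2c1` gives 14900 nM
compound 2 `COc1cc(NC(C)CCCNC(=O)NCCNC(c2ccccc2)(c2ccccc2)c2ccccc2)c2ncccc2c1` gives > 171000 nM
compound 3 `COc1cc(NC(C)CCCNC(=O)NNC(=O)/C=C/c2ccc(OC)c(OC)c2)c2ncccc2c1` gives 37000 nM

All three share one core and were tested in an ADME assay on L6 cells (Rattus norvegicus) for cytotoxicity, read by resazurin assay, with a stated time of 70 h; on this read-out higher numbers stand for weaker inhibition and lower numbers for stronger inhibition. Compound 2 gives only > 171000 nM, which is a limit of the assay and not a number (the limit of > 171000 nM in this assay, at which 1 of the 3 values shown sits). Of the two numbers, compound 3 gives the higher one, and its gap to compound 1 lies beyond the scatter. Compound 4 `COc1cc(NC(C)CCCNC(=O)NNC(=O)Nc2ccc(Cl)cc2)c2ncccc2c1` is not yet measured. It differs from compound 3 in one place: (4-chlorophenyl)amino in place of 2-(3,4-dimethoxyphenyl)ethenyl on a carbonyl carbon. For the measured compounds named here, no measured pair shows this change, so no step size is known for it. In this assay compound 4 is expected to give 40000 nM, in a range from 15000 nM to 120000 nM. The expected step is a 1.1-fold higher number from compound 3 to compound 4 (0.03 log units; within the scatter), none beyond the scatter.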

Compound 4, half-maximal inhibitory concentration: 91900 nM
Beside the measured number, compound 4's estimate is 2.3-fold (0.36 log units) below it; the range from low to high includes it.
By their numbers in this assay, from the lowest: compound 1; then compound 3; then compound 4. At a limit, above all of these: compound 2.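

In this assay, swapping the group on this carbonyl carbon gives a 2.5-fold higher number from compound 3 to compound 4 (0.40 log units; beyond the scatter), so this position does respond to change, though modestly. The higher number means weaker inhibition of the cells, even though (4-chlorophenyl)amino brings fewer heavy atoms than 2-(3,4-dimethoxyphenyl)ethenyl. Nothing measured here accounts for this step. Going by these compounds, what a plain phenylamino group would give at this carbonyl carbon remains open. So does whether the chlorine, the added nitrogen or the loss of the double bond outside the rings carries the step.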